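Cyclopentylsulfanyl in place of methoxypropoxy at the pyridine ether position

This account rests on a few compounds, and the source may have more. Where it says the series, first, only, none or still open, it means among the compounds named here.

Compound 1 `CCCOc1nc(C(C)(C)C)ccc1CNC(=O)C(C)c1ccc(NS(C)(=O)=O)c(F)c1`: 1.7 nM
Compound 2 `COCCCOc1nc(C(C)(C)C)ccc1CNC(=O)C(C)c1ccc(NS(C)(=O)=O)c(F)c1`: 5.6 nM

In an assay on cells for antagonist activity at transient receptor potential cation channel subfamily V member 1 (Homo sapiens), read by FLIPR and calcium flux, with a stated time of 6 min (on this read-out higher numbers stand for weaker inhibition and lower numbers for stronger inhibition), compound 2 gives 5.6 nM, the higher of the two numbers; compound 1 gives 1.7 nM, and the step of a 3.3-fold higher number from compound 1 to compound 2 (0.52 log units; beyond the scatter) lies beyond the scatter. Compound 3 `CC(C(=O)NCc1ccc(C(C)(C)C)nc1SC1CCCC1)c1ccc(NS(C)(=O)=O)c(F)c1` carries cyclopentylsulfanyl in place of 3-methoxypropoxy on an aromatic carbon. Among the compounds with values here, only that one step bears on this change, and it shows that the methoxy cost potency; compound 3 drops the methoxy, but the sulfur and the ring have no precedent here. The estimate for compound 3 is therefore 3 nM (range 0.8 nM to 12 nM), a step of a 1.9-fold lower number from compound 2 to compound 3 (0.27 log units; within the scatter) expected toward compound 1.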

Compound 3, inhibition constant: 2.5 nM
For compound 3 the middle estimate is 1.2-fold (0.08 log units) above the measured one, and the stated range covers the measured number.
By their numbers in this assay, from the lowest: compounds 1 and 3 (each within the scatter of the next); then compound 2.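

In this assay the position accepts cyclopentylsulfanyl, which brings a ring and a sulfur, in place of 3-methoxypropoxy, with a 2.2-fold lower number from compound 2 to compound 3 (0.35 log units; beyond the scatter). Against the propoxy of compound 1, the same group gives a 1.5-fold higher number from compound 1 to compound 3 (0.17 log units; within the scatter), so in compound 3 neither an oxygen on the aromatic carbon nor an open chain is needed for a low number. No measurement given here accounts for either step.

The compounds shown do not separate the sulfur from the ring: cyclopentyloxy or propylsulfanyl at this position would do so. As far as these compounds go, how an amine would read here also remains open.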